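Cyclohexyl for Phenyl at the Amide-Type Nitrogen

The compounds below may be only part of what the source reports. "The series", "measured", "known", "first", "only" and "open" are said of these compounds alone.

Compound 1 `O=C(Nc1ccccc1)N(Cc1ccccn1)n1cnnc1` is the reference point of the series. In a functional assay on MDA-MB-231 cells (Homo sapiens) for cytotoxicity, read by MTT assay, with a stated time of 48 h (a lower number here means a stronger inhibitor, a higher number a weaker inhibitor), compound 1 gives only a limit, > 50000 nM. Compound 2 `COc1ccc(CN(C(=O)Nc2ccc(Cl)cc2)n2cnnc2)cc1OC` in this assay also gives only a limit, > 50000 nM. Compound 3 `Cc1ccsc1CN(C(=O)Nc1cccc(C#N)c1)n1cnnc1` in this assay likewise gives only a limit, > 50000 nM. Going by the values given here, all three measured values sit at the limit of > 50000 nM in this assay, at which 3 of the 3 values shown sit, so no step between measured compounds can be read, and the series so far shows no measurable inhibition at all.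

Compound 4 `O=C(NC1CCCCC1)N(Cc1ccccn1)n1cnnc1` is the next compound to be measured. It differs from compound 1 by cyclohexyl in place of phenyl on an amide-type nitrogen. None of the three measured compounds shows whether a change of this kind moves the read-out, and the starting point is itself a limit rather than a number. In this assay the expected step is a step that the limit leaves unreadable from compound 1 to compound 4, that is, none beyond the scatter. Compound 4 is expected to give about 60000 nM in this assay, with a range from 20000 nM to 200000 nM, and most probably only a limit again.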

Compound 4, half-maximal inhibitory concentration: 44100 nM
Beside the measured number, compound 4's estimate is 1.4-fold (0.13 log units) above it, within the range that was stated.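

Compound 4 is the only compound shown that gives a number rather than a limit in this assay, so a change on the amide-type nitrogen can bring the read-out into the measurable range. Cyclohexyl in place of phenyl gives an at least 1.1-fold lower number from compound 1 to compound 4 (0.05 log units; that floor lies within the scatter), and this supports no claim of a gain beyond the scatter. That step is only a floor, because compound 1 gives a limit and not a number: the limit of > 50000 nM in this assay, at which 3 of the 4 values shown sit.

From the compounds shown here alone, the true size of the step remains open, as does whether the aromatic ring itself matters at this position or any group other than phenyl would serve. Also open, going by these compounds, is whether cyclopentyl, a longer chain such as n-hexyl, or a benzyl group on this nitrogen would give a number in this assay.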